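A few compounds are considered here, and "the series" means these few. Any claim that something is new, unique, unknown or untested is made for them only; others in the source may bear on it.

Series notes, compounds measured in a functional assay on HEK293 cells for agonist activity at Vasopressin V2 receptor (Homo sapiens), read by a luciferase reporter and cAMP accumulation; on this read-out lower numbers stand for an effect already at smaller amounts and higher numbers for an effect only at larger amounts of compound:

- compound 1, `Cc1cc(C(=O)N2CCCCc3ccccc32)ccc1CNC(=O)NCC(=O)N(C)C`, gives 58 nM
- compound 2, `CCN(CC)C(=O)[C@@H]1CCCN1C(=O)NCc1ccc(C(=O)N2CCCCc3ccccc32)cc1C`, gives 350 nM
- compound 3, `Cc1cc(C(=O)N2CCCCc3ccccc32)ccc1CNC(=O)N1CCC[C@@H]1C(=O)N(C)C`, gives 380 nM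

Compound 3 stands at the highest of the three numbers in this assay. Its nearest neighbour is compound 2, whose step a 1.1-fold higher number from compound 2 to compound 3 (0.04 log units; within the scatter) lies within the scatter, so the two cannot be ordered. Among the measured compounds shown here, the only step beyond the scatter that reaches compound 3 is a 6.6-fold higher number from compound 1 to compound 3 (0.82 log units; beyond the scatter), which matches the parallel step a 6.0-fold higher number from compound 1 to compound 2 (0.78 log units; beyond the scatter): closing the chain of compound 1 into a pyrrolidine raises the number by a modest amount whichever dialkylamide sits on it.

Compound 4, `Cc1cc(C(=O)N2CCCCc3ccccc32)ccc1CNC(=O)N1C[C@H](O)C[C@H]1C(=O)N(C)C`, keeps the pyrrolidine of compound 3 and differs only in this: 2-(dimethylcarbamoyl)-4-hydroxypyrrolidin-1-yl in place of 2-(dimethylcarbamoyl)pyrrolidin-1-yl on a carbonyl carbon. For the measured compounds named here, none of the measured steps touches this position; the one step that alters the pyrrolidine substituent, a 1.1-fold higher number from compound 2 to compound 3 (0.04 log units; within the scatter), is within the scatter. There is therefore no basis in the series for expecting a shift beyond the scatter in this assay in either direction, and the expected step is a 1.1-fold higher number from compound 3 to compound 4 (0.02 log units; within the scatter). Compound 4 is accordingly estimated at 400 nM, with a range from 150 nM to 1100 nM.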

Compound 4, half-maximal effective concentration: 2.3 nM
The estimate for compound 4 lay 170-fold (2.24 log units) above the measured number; measured number below the stated range.
By their numbers in this assay, from the lowest: compound 4; then compound 1; then compounds 2 and 3 (each within the scatter of the next).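

In this assay, among the compounds shown here, the 2-(dimethylcarbamoyl)pyrrolidin-1-yl group on the carbonyl carbon proves far more responsive than the earlier changes suggested, since introducing the hydroxyl gives a 170-fold lower number from compound 3 to compound 4 (2.22 log units; beyond the scatter) and is the largest change so far. The effect also holds against the diethyl amide, with a 150-fold lower number from compound 2 to compound 4 (2.18 log units; beyond the scatter) as the comparison, and it more than reverses the loss seen on closing the chain into a pyrrolidine, with a 25-fold lower number from compound 1 to compound 4 (1.40 log units; beyond the scatter) placing the hydroxylated ring ahead of the open-chain urea. Nothing available explains why a single hydroxyl has so large an effect.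

From the compounds shown here alone, whether the hydroxyl itself is required remains open, as a methoxy group, a fluorine atom or an amine at the same ring carbon would be needed to separate it from other substituents. The compounds shown also carry this hydroxyl in only one configuration and on only the dimethyl amide, so the contribution of the added stereocentre and the outcome with the diethyl amide of compound 2 are both unresolved.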